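The compounds below may be only part of what the source reports. "The series", "measured", "known", "first", "only" and "open" are said of these compounds alone.

Measured so far in an ADME assay on Huh-7 cells (Homo sapiens) for cytotoxicity, read by MTT assay, with a stated time of 96 h (on this read-out lower numbers stand for higher toxicity in this test and higher numbers for lower toxicity in this test), are three compounds

compound 1 `COc1cc(NCc2ccc(Cl)s2)ccc1-c1cnco1` gives 43200 nM here
compound 2 `COc1cc(NCc2cncs2)ccc1-c1cnco1` gives 68900 nM here
compound 3 `COc1cc(NCc2ccc(Br)s2)ccc1-c1cnco1` gives 39400 nM here

Compound 3 sits within the scatter of both others, as a 1.1-fold lower number from compound 1 to compound 3 (0.04 log units; within the scatter) and a 1.7-fold lower number from compound 2 to compound 3 (0.24 log units; within the scatter) both show. The change leading to compound 4 `COc1cc(NCc2ccsc2)ccc1-c1cnco1` is thiophen-3-yl in place of 5-bromothiophen-2-yl on a saturated chain carbon bound to a nitrogen on an aromatic ring and the rest of the molecule stays the same. Exchanging the ring at this place gave a 1.6-fold higher number from compound 1 to compound 2 (0.20 log units; within the scatter) and all three measured steps stayed within the scatter. Going by the values given here, no measured compound carries thiophen-3-yl, so this is an extrapolation. No step beyond the scatter is expected, and the estimated step is a 1.4-fold higher number from compound 3 to compound 4 (0.14 log units; within the scatter) in size. For compound 4 the estimated value is 55000 nM with an expected range from 30000 nM to 100000 nM once it is measured.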

Compound 4, half-maximal cytotoxic concentration: 63100 nM
Estimate against measurement, compound 4: 1.1-fold (0.06 log units) below; measured number inside the range.
By their numbers in this assay, from the lowest: compounds 3, 1, 4 and 2 (each within the scatter of the next).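

In this assay, thiophen-3-yl on this saturated chain carbon cannot be told apart from the three rings before it, with a 1.6-fold higher number from compound 3 to compound 4 (0.20 log units; within the scatter) and a 1.5-fold higher number from compound 1 to compound 4 (0.16 log units; within the scatter) and a 1.1-fold lower number from compound 2 to compound 4 (0.04 log units; within the scatter) all inside the scatter. A thiophene with no halogen therefore reads like the bromo and chloro thiophenes and the thiazole, so all four rings tested at this place give matching results. Nothing measured here explains this result. Still open, from the compounds shown here alone, is whether a group of another kind at this place, such as an amine, a carboxylic acid or a longer chain, would give a step beyond the scatter.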